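This account rests on a few compounds, and the source may have more. Where it says the series, first, only, none or still open, it means among the compounds named here.

Measured compounds:
compound 1, `O=C(O)Cc1sc(C(c2ccccc2)c2ccccn2)nc1-c1ccc(Cl)cc1`, 1900 nM
compound 2, `N#Cc1ccc(-c2nc(C(c3ccc(F)cc3)c3ccc(F)cc3)sc2CC(=O)O)cc1`, 1500 nM

Both compounds were tested in an in vitro functional assay on HEK285-7 cells for antagonist activity at prostaglandin D2 receptor 2 (Homo sapiens), read by BRET and beta-arrestin recruitment; on this read-out higher numbers stand for weaker inhibition and lower numbers for stronger inhibition. Compound 1 gives 1900 nM and compound 2 gives 1500 nM in this assay. Compound 2 holds the lower of the two numbers, but its gap to compound 1 lies within the scatter of repeated measurements, so the two cannot be told apart on this read-out; neither counts as the stronger inhibitor.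

Compound 3, `Cc1cc(-c2nc(C(c3ccc(F)cc3)c3ccc(F)cc3)sc2CC(=O)O)cnc1N`, keeps the rest of compound 2 unchanged and alters one ring: 6-amino-5-methylpyridin-3-yl in place of 4-cyanophenyl on an aromatic carbon. Within the data shown here, no measured pair shows what such an exchange does at this position, so there is no step to lean on, and only the two values above inform the guess. The expectation for compound 3 is a step from compound 2 of about the size of the scatter, leaning toward a somewhat higher number, as a 1.7-fold higher number from compound 2 to compound 3 (0.22 log units; within the scatter). The estimate for compound 3 in this assay is 2500 nM, with a range from 600 nM to 10000 nM.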

Compound 3, half-maximal inhibitory concentration: > 100000 nM
Compound 3: a limit, no number; the forecaster's own chance of this, stated with the estimate: 10%; middle value at least 40-fold (1.60 log units) from the limit.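

This position, on an aromatic carbon next to the ring nitrogen and next to the ring atom that bears a carboxymethyl group, does not accept every six-membered aromatic ring: 6-amino-5-methylpyridin-3-yl in place of 4-cyanophenyl gives an at least 66-fold higher number from compound 2 to compound 3 (1.82 log units; beyond the scatter) in this assay. The group that leaves and the group that enters hold the same number of heavy atoms, so a large loss of inhibition here can occur with no change in that count. Compound 3 stands at a limit of the assay, not at a number, so the true size of the step stays unknown: the limit of > 100000 nM in this assay, at which 1 of the 3 values shown sits.

The exchange alters several things at once: the nitrile goes, while a ring nitrogen, an amine and a methyl group arrive, and the compounds shown cannot say which of these carries the loss. From the compounds shown here alone, whether a plain pyridin-3-yl ring, or a phenyl ring bearing only an amine or only a methyl group, would stay close to compound 2 remains open.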